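The source may hold more compounds than are shown below. What is called first, only, known or untested is meant among the compounds shown, and "the series" means these compounds.

Measured compounds and their values:
- compound 1, `Nc1cc(N)c2nc(-c3ccccc3)c(NCc3ccc(Cl)c(Cl)c3)nc2c1`: 64600 nM
- compound 2, `CCOC(=O)[C@H](CCC(=O)O)NC(=O)c1ccc(Sc2nc3cc(N)cc(N)c3nc2-c2ccccc2)cc1`: < 100000 nM

In a functional assay on HOP-62 cells (Homo sapiens) for inhibition, read by sulforhodamine B assay, with a stated time of 48 h (a lower number here means that less compound is tolerated, a higher number that more compound is tolerated), compound 1 gives 64600 nM. Compound 2 returns no number in this assay, only a limit, < 100000 nM. Within the data shown here, compound 1 therefore stands as the single actual value in the set; the other entry is a limit of the assay (the limit of < 100000 nM in this assay, at which 1 of the 2 values shown sits), so no ordering of the two can be read off.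

Compound 3, `COc1ccc(CNc2nc3cc(N)cc(N)c3nc2-c2ccccc2)cc1`, is not yet measured. It differs from compound 1 in one place: 4-methoxyphenyl in place of 3,4-dichlorophenyl on a saturated chain carbon bound to a nitrogen on an aromatic ring. Among the measured compounds shown here, no step between two measured compounds is available to calibrate what such an exchange does here, so the expectation rests on the single value of compound 1 alone.

The change is expected to shift the result little, if at all, beyond the usual scatter, with any drift more likely toward a higher number than a lower one. The expected step from compound 1 to compound 3 in this assay is a 1.2-fold higher number from compound 1 to compound 3 (0.09 log units; within the scatter). Compound 3 is estimated to give 80000 nM in this assay, within a range of 30000 nM to 160000 nM, and a limit rather than a number is a real possibility.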

Compound 3, concentration lethal to 50% of the cells: 69200 nM
Compound 3: the middle estimate sits 1.2-fold (0.06 log units) above what was measured, within the range that was stated.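

In this assay, among these compounds, the exchange of 3,4-dichlorobenzyl for 4-methoxybenzyl provides the first step that can be read at this position, and it is a 1.1-fold higher number from compound 1 to compound 3 (0.03 log units; within the scatter). On this saturated chain carbon bound to a nitrogen on an aromatic ring, 3,4-dichlorophenyl can therefore give way to 4-methoxyphenyl, replacing two chlorine atoms with a group that carries a hydrogen-bond acceptor, without moving the read-out beyond the scatter. Compound 2 still gives a limit rather than a number, so it cannot be placed on this scale: the limit of < 100000 nM in this assay, at which 1 of the 3 values shown sits.

Among the compounds shown here, this single step compares only two substituted phenyl rings with the same number of heavy atoms, so it cannot show whether the read-out would also hold with a very different group at this position. A carboxylic acid or an amine on the ring, a longer chain between the ring and the nitrogen, or a plain methyl in place of the whole benzyl group could each test how far this tolerance extends.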